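The compounds below may be only part of what the source reports. "The series", "measured", "known", "first", "only" and "open" are said of these compounds alone.

Compound 2 `O=C(Nc1ccc(Cl)cc1)C1CCCN(C(=O)c2cccc(-c3nccs3)c2)C1` gives the highest of the three numbers in an ADME assay on PC-3 cells (Homo sapiens) for cytotoxicity, read by WST assay, tested at 100 uM (a higher number here means more inhibition at the concentration tested (going by the name of the read-out), a lower number less inhibition), with compound 3 `O=C(Nc1cccc([N+](=O)[O-])c1)C1CCCN(C(=O)c2cc(C(F)(F)F)cc(C(F)(F)F)c2)C1` and compound 1 `O=C(Nc1cccc(Oc2ccccn2)c1)C1CCCN(C(=O)c2cc(C(F)(F)F)cc(C(F)(F)F)c2)C1` both lower. In this assay compound 2 gives 32%, compound 3 gives 9% and compound 1 gives 0%. Compound 4 `CS(=O)(=O)Nc1cccc(C(=O)N2CCCC(C(=O)Nc3ccc(Cl)cc3)C2)c1` differs from compound 2 at the benzoyl side: methanesulfonamido in place of 1,3-thiazol-2-yl on an aromatic carbon. Among the compounds with values here, the only measured step, a number 9 percentage points higher from compound 1 to compound 3 (within the scatter), changes the anilide ring and not the benzoyl ring, so no measured step bears on this change. The account therefore expects no step beyond the scatter, a number 10 percentage points lower from compound 2 to compound 4 (within the scatter), and estimates compound 4 at 22% in this assay, between 2% and 42%.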

Compound 4, a percentage reported as inhibition, at one concentration (the size of the read-out at that concentration, not a potency): 3%
Compound 4: the middle estimate sits 19 percentage points above what was measured; the range from low to high includes it.
By their numbers in this assay, from the lowest: compounds 1, 4 and 3 (each within the scatter of the next); then compound 2.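

Within the data shown here, the first step beyond the scatter in this assay falls on the benzoyl ring: methanesulfonamido in place of 1,3-thiazol-2-yl, on an aromatic carbon meta to a large group, gives a number 29 percentage points lower from compound 2 to compound 4 (beyond the scatter) in this single pair. The only earlier step changed the anilide ring and stayed within the scatter, so this position is the first shown where a change moves the read-out. Nothing available explains the size of this step.

Going by these compounds, it remains open whether the ring of 1,3-thiazol-2-yl itself matters, which a phenyl ring or an amine at this carbon could test. On these data alone, it is also open whether the step holds with another anilide ring.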